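The source may hold more compounds than are shown below. What is called first, only, known or untested is meant among the compounds shown, and "the series" means these compounds.

Measured compounds in this series:
compound 1 `CCCn1cc(S(=O)(=O)c2ccc(CNC(=O)N3Cc4ccncc4C3)cc2)cn1`, 105000 nM
compound 2 `O=C(NCc1ccc(S(=O)(=O)C2CCOCC2)cc1)N1Cc2ccncc2C1`, 206000 nM

In a physicochemical assay for solubility, in phosphate buffer, with a stated time of 24 h, at pH 7.4, tested at 100 uM (a lower number here means a less soluble compound, a higher number a more soluble compound), compound 2 gives the higher of the two numbers, yet the step of a 2.0-fold higher number from compound 1 to compound 2 (0.29 log units; within the scatter) lies within the scatter, so the two compounds cannot be ordered. Compound 3 `O=C(NCc1ccc(S(=O)(=O)N2CCC[C@@H](O)C2)cc1)N1Cc2ccncc2C1` is the next compound. The change from compound 2 is 3-hydroxypiperidin-1-yl in place of oxan-4-yl on a sulfonyl sulfur. Among the measured compounds shown here, only the step from compound 1 to compound 2 bears on it, and that step was within the scatter. For compound 3 no step beyond the scatter is therefore expected in this assay, with an estimated step of a 1.2-fold higher number from compound 2 to compound 3 (0.08 log units; within the scatter). Compound 3 is expected at 250000 nM, within 120000 nM to 500000 nM.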

Compound 3, solubility: 216000 nM
For compound 3 the middle estimate is 1.2-fold (0.06 log units) above the measured one; the measured number falls inside the stated range.
By their numbers in this assay, from the lowest: compounds 1, 2 and 3 (each within the scatter of the next, the first and the last beyond it).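

At the sulfonyl sulfur, 3-hydroxypiperidin-1-yl in place of oxan-4-yl gives a 1.0-fold higher number from compound 2 to compound 3 (0.02 log units; within the scatter) in this assay, so these two groups cannot be ordered. Among the compounds shown here, in place of 1-propyl-1H-pyrazol-4-yl, the same group gives a 2.1-fold higher number from compound 1 to compound 3 (0.31 log units; beyond the scatter), the only step beyond the scatter, and a modest one. No available data explain either step.

Open, going by these compounds, is how a carboxylic acid or an open-chain amine on the sulfonyl sulfur would compare in this assay. Also open, on these data alone, is the opposite stereocentre of 3-hydroxypiperidin-1-yl.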